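The source may hold more compounds than are shown below. What is called first, only, known or untested is meant among the compounds shown, and "the series" means these compounds.

In a functional assay on J774 cells (Mus musculus) for cytotoxicity, read by resazurin assay (a lower number here means a stronger inhibitor, a higher number a weaker inhibitor), compound 1 `OCCCCCC(O)c1ccc(-c2ccccc2)cc1` gives 22000 nM, and compound 2 `OCCCCCC(O)c1ccc(-c2ccc(Br)cc2)cc1` gives 20000 nM. Compound 3 `Cc1cccc(-c2ccc(C(O)CCCCCO)cc2)c1` has no number, only a limit: > 100000 nM. Of the three values in hand, that of compound 3 alone stands at the limit of > 100000 nM in this assay, at which 1 of the 3 values shown sits.

Compound 4 `OCCCCCC(O)c1ccc(-c2ccc(O)cc2)cc1` has not yet been measured. It differs from compound 3 by 4-hydroxyphenyl in place of 3-methylphenyl on an aromatic carbon, with 4-hydroxyphenyl in place of 3-methylphenyl on an aromatic carbon.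

For the measured compounds named here, three measured steps bear on this change. With bromo in place of hydrogen, a 1.1-fold lower number from compound 1 to compound 2 (0.04 log units; within the scatter) stays within the scatter. With methyl in place of hydrogen, an at least 4.5-fold higher number from compound 1 to compound 3 (0.65 log units; beyond the scatter) lies beyond it. With 3-methylphenyl in place of 4-bromophenyl, an at least 5.0-fold higher number from compound 2 to compound 3 (0.69 log units; beyond the scatter) also lies beyond it.

Going by the values given here, the only methyl-bearing compound is thus the one at the limit, while the unsubstituted and 4-bromophenyl compounds share a similar value. With just three compounds, this is thin support. Compound 4 gives up the 3-methylphenyl and carries a 4-substituted phenyl, as compound 2 does at 20000 nM, so it is expected to return towards that level. The expected change, of at least modest size and towards a lower number in this assay, is an at least 3.3-fold lower number from compound 3 to compound 4 (0.52 log units; beyond the scatter). The estimate for compound 4 is 30000 nM, with an expected range of 10000 nM to 90000 nM.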

Compound 4, half-maximal inhibitory concentration: 15000 nM
Compound 4: middle estimate off by 2.0-fold (0.30 log units), on the high side; the measured number falls inside the stated range.
By their numbers in this assay, from the lowest: compounds 4, 2 and 1 (each within the scatter of the next). At a limit, above all of these: compound 3.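

In this assay, the new step of a 1.3-fold lower number from compound 2 to compound 4 (0.12 log units; within the scatter) and the step of a 1.5-fold lower number from compound 1 to compound 4 (0.17 log units; within the scatter) both stay within the scatter, so hydroxy, bromo and hydrogen on this aromatic carbon cannot be told apart by their numbers. The value of compound 3, > 100000 nM, is a limit and not a number. Measured against that limit, an at least 6.6-fold lower number from compound 3 to compound 4 (0.82 log units; beyond the scatter) lies beyond the scatter, which shows that a polar-free comparison is not needed to place compound 3 on its own: among the four compounds, the one with 3-methylphenyl is the only one that stands apart, while compound 1, compound 2 and compound 4 form a single group.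

It remains open whether the methyl itself or its place on the phenyl ring marks out compound 3, since a 4-methylphenyl group is not among the compounds shown. For the compounds shown here, it is also open how this assay would read an amine or a carboxylic acid on the same aromatic carbon, or a longer chain in place of the one these four compounds share.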